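This account rests on a few compounds, and the source may have more. Where it says the series, first, only, none or still open, it means among the compounds named here.

Measured in a functional assay on FM3A cells (Mus musculus) for inhibition; on this read-out higher numbers stand for weaker inhibition and lower numbers for stronger inhibition:
- compound 1 `C/C(=C\COC(=O)Nc1ccccc1)C1=CC(=O)C(C)(C)O1`: > 200 ug/mL, a limit of the assay and not a number
- compound 2 `COc1ccc(/C=C/C=C(\C)C2=CC(=O)C(C)(C)O2)cc1`: 25 ug/mL

Compound 1 has no numerical value on this read-out: it stands at the limit of > 200 ug/mL in this assay, at which 1 of the 2 values shown sits. Among the measured compounds shown here, compound 2 is the only compound here with a number, and it differs from compound 1 in more than one place. For the measured compounds named here, no step between measured compounds that differ in one place is therefore available, and the expectation rests on the structural change alone.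

Compound 3 `C/C(=C\COC(=O)NCc1ccccc1)C1=CC(=O)C(C)(C)O1` keeps the core of compound 1 and carries benzyl in place of phenyl on an amide-type nitrogen. The change is small in what is counted, so in this assay only a small step is expected, if any, and compound 3 is expected to remain a weak inhibitor. A number would necessarily fall on the side of stronger inhibition, but a second limit is just as plausible. The expected at least 1.5-fold lower number from compound 1 to compound 3 (0.18 log units; that floor lies within the scatter) is modest. Compound 3 is estimated at 130 ug/mL, with an expected range of 50 ug/mL to 300 ug/mL.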

Compound 3, half-maximal inhibitory concentration: 8.1 ug/mL
Compound 3: middle estimate off by 16-fold (1.21 log units), on the high side; the measured number lies below the stated range.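

In this assay compound 1 gives > 200 ug/mL as a limit of the assay and not a number. Benzyl in place of phenyl on an amide-type nitrogen gives an at least 24-fold lower number from compound 1 to compound 3 (1.39 log units; beyond the scatter) on the shared core, so this position responds strongly to a change that is small in what is counted, and compound 3 moves the series from a limit to a measured number. The step is a floor and its full size cannot be read, because one end of it rests on a limit: the limit of > 200 ug/mL in this assay, at which 1 of the 3 values shown sits.

On these data alone, whether the gain continues with a longer chain on the same nitrogen, such as phenethyl, or depends on the aromatic ring, as a comparison of benzyl with cyclohexylmethyl would show, remains open. Among the compounds shown here, also open is whether the amide hydrogen matters, which a methyl group on that nitrogen in the compound 3 series would address, and with only this one pair differing in one place, no trend for the position can yet be stated.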